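The compounds below may be only part of what the source reports. "The series", "measured", "known", "first", "only" and "open" are said of these compounds alone.

Working notes on the series. Solubility is followed in a physicochemical assay for solubility, in phosphate buffer, measured as kinetic solubility, with a stated time of 1 h, at pH 7.4; a lower number here means a less soluble compound, a higher number a more soluble compound. Compound 3 `COc1ccc2nc(C)cc(OCC(=O)Nc3ccccc3)c2c1` gives 63000 nM in this assay. Compound 2 `CCC(Oc1cc(C)nc2ccc(OC)cc12)C(=O)Nc1cc(C)cc(C)c1` gives 123000 nM in this assay; the gap between compound 3 and compound 2 lies within the usual scatter, so the two stand side by side and neither can be called the more soluble. Compound 1 `Cc1cc(C)cc(NC(=O)COc2cc(C)nc3ccc(OCc4ccccc4)cc23)c1` returns only a limit in this assay, < 1000 nM, which is the limit of < 1000 nM in this assay, at which 1 of the 3 values shown sits. Among the compounds with values here, no two measured compounds differ in a single place, so no measured step is known in this set.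

Compound 4 `COc1ccc2nc(C)cc(OCC(=O)Nc3nccs3)c2c1` is not yet measured. It differs from compound 3 in one place: 1,3-thiazol-2-yl in place of phenyl on an amide-type nitrogen. Within the data shown here, with no measured step of this kind to lean on, the change is expected to move this assay by no more than the scatter, with no firm direction. Compound 4 is therefore expected to give 70000 nM in this assay, between 20000 nM and 200000 nM. The step expected from this change is a 1.1-fold higher number from compound 3 to compound 4 (0.05 log units; within the scatter).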

Compound 4, solubility: 54000 nM
Compound 4: middle estimate off by 1.3-fold (0.11 log units), on the high side; low and high end bracket the measured number.
By their numbers in this assay, from the lowest: compounds 4, 3 and 2 (each within the scatter of the next, the first and the last beyond it). At a limit, below all of these: compound 1.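

Within the data shown here, the first single-place step in this assay now stands at this position: 1,3-thiazol-2-yl in place of phenyl on an amide-type nitrogen gives a 1.2-fold lower number from compound 3 to compound 4 (0.07 log units; within the scatter). Exchanging one six-membered aromatic ring of carbon only for one five-membered aromatic ring with 2 hetero atoms, which carries 2 hydrogen-bond acceptors, therefore leaves compound 3 and compound 4 side by side, with neither to be called the more soluble. Nothing measured here gives a cause for this step.

The compounds shown leave open how a phenyl ring bearing a carboxylic acid, or a longer chain ending in an amine, would read on the same amide-type nitrogen. They also leave open whether the same exchange would read alike with the other substituents of compound 1 and compound 2 in place.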